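Sulfonyl substituent changes across a shared core

A few compounds are considered here, and "the series" means these few. Any claim that something is new, unique, unknown or untested is made for them only; others in the source may bear on it.

Measured so far in an assay on liver for inhibition of sterol O-acyltransferase 1 (Rattus norvegicus), using microsomes; on this read-out lower numbers stand for stronger inhibition and higher numbers for weaker inhibition:
- compound 1 `CCCCN(C)S(=O)(=O)NC(=O)Nc1c(C(C)C)cccc1C(C)C`: 2300 nM
- compound 2 `CCCN(CCC)S(=O)(=O)NC(=O)Nc1c(C(C)C)cccc1C(C)C`: 1100 nM
- compound 3 `CCCCCCNS(=O)(=O)NC(=O)Nc1c(C(C)C)cccc1C(C)C`: 8100 nM

Compound 3 stands at the highest number of the three: a 3.5-fold higher number from compound 1 to compound 3 (0.55 log units; beyond the scatter), and a 7.4-fold higher number from compound 2 to compound 3 (0.87 log units; beyond the scatter). Compound 1 and compound 2 are also separated: a 2.1-fold lower number from compound 1 to compound 2 (0.32 log units; beyond the scatter).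

Compound 4 `CCCCCCC(C)OS(=O)(=O)NC(=O)Nc1c(C(C)C)cccc1C(C)C` differs from compound 3 in one place: (1-methylheptyl)oxy in place of hexylamino on a sulfonyl sulfur. All three measured steps vary this same position on the sulfonyl sulfur, so all bear on the step to compound 4, but none of them exchanges the nitrogen for an oxygen there; a direct precedent is missing. The two steps ending at compound 3 show hexylamino at the weak end of the series, and compound 4, like compound 1 and compound 2, carries no hydrogen-bond donor at that position. On that basis a modest move toward lower numbers is expected, about a 2.0-fold lower number from compound 3 to compound 4 (0.31 log units; beyond the scatter), with wide uncertainty given the new oxygen link. Compound 4 is therefore estimated at 4000 nM, within the range 1000 nM to 16000 nM.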

Compound 4, half-maximal inhibitory concentration: 35000 nM
Compound 4: middle estimate off by 8.8-fold (0.94 log units), on the low side; measured number above the stated range.
By their numbers in this assay, from the lowest: compound 2; then compound 1; then compound 3; then compound 4.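

In this assay, (1-methylheptyl)oxy on the sulfonyl sulfur gives the highest number of the series, with a 4.3-fold higher number from compound 3 to compound 4 (0.64 log units; beyond the scatter), so removing the hydrogen-bond donor of hexylamino does not by itself lower the number at this position. The gaps to the two amino groups that also lack this donor are wider, with a 15-fold higher number from compound 1 to compound 4 (1.18 log units; beyond the scatter) and a 32-fold higher number from compound 2 to compound 4 (1.50 log units; beyond the scatter), so compound 4 goes against the link between having no donor there and lower numbers that compound 1 and compound 2 had suggested. No available evidence accounts for this rise.

Compound 4 changes the linking atom and the chain together, which leaves the contribution of each open. A hexyloxy group or a (1-methylheptyl)amino group on the same sulfur would separate the two.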